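From Methyl to Chloro on Compound 1

The source may hold more compounds than are shown below. What is called first, only, known or untested is meant among the compounds shown, and "the series" means these compounds.

In an ADME assay on microsomes (Rattus norvegicus) for metabolic stability (a higher number here means that the compound lasts longer, a lower number that the compound disappears faster), compound 1 `Cc1ccc(C2CC=NN2C(=O)C(C)(C)C)cc1` gives 0.0383 h, at the low end of the three numbers available, together with compound 2 `Cc1ccc(C2CC=NN2C(=O)C(C)(C)C)cc1F` at 0.0433 h. Compound 3 `O=C(C1CCCCC1)N1N=CCC1c1ccccc1` differs from compound 1 in more than one place. Compound 3 gives 0.0833 h, a number higher than that of compound 1 by more than the scatter.

Compound 4 `CC(C)(C)C(=O)N1N=CCC1c1ccc(Cl)cc1` comes from compound 1 through (chloro in place of methyl on an aromatic carbon), which puts chloro in place of methyl on an aromatic carbon, para to a large group. For the measured compounds named here, the only measured step, a 1.1-fold higher number from compound 1 to compound 2 (0.05 log units; within the scatter), is fluoro in place of hydrogen on an aromatic carbon, so it is a different exchange and bears only loosely on this one. Going by the values given here, no measured step removes the methyl alone. Compound 3 also lacks that methyl, and its value of 0.0833 h hints weakly at a higher number, though its other difference clouds the comparison.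

The expected change is small and upward, a 1.4-fold higher number from compound 1 to compound 4 (0.16 log units; within the scatter). For compound 4 the estimated half-life is 0.055 h, with an expected range from 0.03 h to 0.11 h.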

Compound 4, half-life: 0.145 h
Beside the measured number, compound 4's estimate is 2.6-fold (0.42 log units) below it, outside the stated range (above it).
By their numbers in this assay, from the lowest: compounds 1, 2, 3 and 4 (each within the scatter of the next, the first and the last beyond it).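

In this assay, chloro in place of methyl on an aromatic carbon, para to a large group, gives a 3.8-fold higher number from compound 1 to compound 4 (0.58 log units; beyond the scatter), so this position responds to this exchange by more than the scatter. The earlier step, a 1.1-fold higher number from compound 1 to compound 2 (0.05 log units; within the scatter), put fluoro in place of hydrogen on an aromatic carbon and stayed within the scatter, so it showed no such response. Nothing available gives a reason for the size of the new step.

The compounds shown do not separate the loss of methyl from the gain of chloro, as none keeps everything else in compound 1 and carries hydrogen at this position. As far as these compounds go, it also remains open whether bromo, methoxy, trifluoromethyl or a nitrile at this position would give a number close to that of compound 4.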